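A few compounds are considered here, and "the series" means these few. Any claim that something is new, unique, unknown or untested is made for them only; others in the source may bear on it.

Working notes on the series. Three compounds share the core of compound 1, `CS(=O)(=O)c1cccc(S(=O)(=O)c2ccc3c(c2)CCC[C@H]3CN)c1`, which in an assay on isolated protein for displacement of a labelled ligand from 5-hydroxytryptamine receptor 6 (Homo sapiens) (a higher number here means a weaker inhibitor, a lower number a stronger inhibitor), gives 3.98 nM. Compound 2, `NC[C@@H]1CCCc2cc(S(=O)(=O)c3c[nH]c4ccccc34)ccc21`, gives in this assay 0.0501 nM. Compound 3, `CNS(=O)(=O)NC[C@@H]1CCCc2cc(S(=O)(=O)c3cccc(F)c3)ccc21`, gives in this assay 1 nM. Among the three numbers, compound 3 stands second highest: compound 1 sits nearest with a higher number, beyond the scatter, and compound 2 sits furthest with a lower number, also beyond the scatter.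

The next step keeps the whole of compound 3 except the group on the amine nitrogen and leads to compound 4, `NC(=O)CNC[C@@H]1CCCc2cc(S(=O)(=O)c3cccc(F)c3)ccc21`. The change is carbamoylmethyl in place of methylsulfamoyl on an amine nitrogen. Within the data shown here, no pair differing in one place has been measured, so the size of this step cannot be read off from the series; a primary amine on the same core with other aryl groups gives both the highest and the lowest number, which says little about a substituted amine.

The step is expected to be small, a 2.0-fold higher number from compound 3 to compound 4 (0.30 log units; within the scatter), at most a modest move toward a higher number. Compound 4 is estimated at 2 nM, with a range from 0.5 nM to 8 nM.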

Compound 4, inhibition constant: 0.1 nM
Beside the measured number, compound 4's estimate is 20-fold (1.30 log units) above it; measured number below the stated range.
By their numbers in this assay, from the lowest: compounds 2 and 4 (each within the scatter of the next); then compound 3; then compound 1.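

The exchange of methylsulfamoyl for carbamoylmethyl on the amine nitrogen gives a 10-fold lower number from compound 3 to compound 4 (1.00 log units; beyond the scatter) in this assay. Among these compounds, this is the first pair that differs in one place, and it shows that the group on this nitrogen can by itself shift the number while the rest of compound 3 stays fixed. Nothing at hand bears on why this exchange shifts the number.

As far as these compounds go, it remains open whether the step is particular to carbamoylmethyl or would also appear with other groups on this nitrogen, such as a methyl, an acetyl or a longer chain ending in a carboxylic acid. From the compounds shown here alone, it is equally open whether the same exchange would give a step of similar size with the aryl groups of compound 1 and compound 2.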